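A swap at the biaryl end of compound 1

The source may report more compounds than this note shows. Statements on the series, on what has been measured and on what is new or still open speak of the compounds shown alone.

Of the compounds shown here, three of one series have been tested in an ADME assay on HepG2 cells (Homo sapiens) for cytotoxicity, read by MTT assay, with a stated time of 72 h; a lower number here means that less compound is tolerated, a higher number that more compound is tolerated. Compound 1 `CC1(c2ccc(-c3ccccc3C#N)cc2)CC(S(=O)(=O)c2ccc(F)cc2)=C(c2ccc(/C(N)=N\O)cc2)O1` gives 58300 nM in this assay. Compound 2 `CC1(Cc2ccccc2)CC(S(=O)(=O)c2ccccc2F)=C(c2ccc(/C(N)=N\O)cc2)O1` gives 61700 nM, a number that sits within the usual scatter of the value for compound 1, so the two cannot be told apart. Compound 3 `CCC1(c2ccccc2OC)CC(S(=O)(=O)c2ccc(F)cc2)=C(c2ccc(/C(N)=N\O)cc2)O1` gives 27000 nM, a lower number than compound 1 that lies beyond the scatter, meaning compound 3 is tolerated at a lower concentration. Compound 1 therefore stands with compound 2 at the tolerated end of the three, while compound 3 stands apart below them.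

Compound 4 `CC1(c2ccc(-c3cccc([N+](=O)[O-])c3)cc2)CC(S(=O)(=O)c2ccc(F)cc2)=C(c2ccc(/C(N)=N\O)cc2)O1` is the next compound to be measured. It differs from compound 1 in one place: 3-nitrophenyl in place of 2-cyanophenyl on an aromatic carbon. Both groups are single aromatic rings carrying one substituent, so the overall shape of the molecule is kept. Going by the values given here, no pair of measured compounds shows this particular change, so its effect has to be estimated without a direct precedent. The expectation is a step from compound 1 to compound 4 of a 1.2-fold lower number from compound 1 to compound 4 (0.07 log units; within the scatter), which would stay within the scatter of repeated measurements. Compound 4 is accordingly expected to give about 50000 nM in this assay, with a range from 25000 nM to 100000 nM.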

Compound 4, half-maximal cytotoxic concentration: > 50000 nM
Compound 4: a limit, no number; the forecaster's own chance of this, stated with the estimate: 15%; the middle value sits exactly at the limit.
By their numbers in this assay, from the lowest: compound 3; then compounds 1 and 2 (each within the scatter of the next).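

In this assay compound 4 gives > 50000 nM, which is a limit of the assay and not a number. The step from compound 1 to compound 4 cannot be read from it. The compounds shown leave open whether 3-nitrophenyl in place of 2-cyanophenyl changes the tolerated concentration at all, and by how much.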